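This account rests on a few compounds, and the source may have more. Where it says the series, first, only, none or still open, it means among the compounds named here.

The measured compounds:
compound 1 `CC(C)(C)c1ccc(C(=O)/C=C/c2ccc([N+](=O)[O-])o2)cc1` — > 100000 nM
compound 2 `O=C(/C=C/c1cccc([N+](=O)[O-])c1)c1ccc(N2CCCCC2)cc1` — "not determined" (no result reported)
compound 3 `O=C(/C=C/c1ccc([N+](=O)[O-])cc1)c1ccc(N2CCCCC2)cc1` — "not determined" (no result reported)

In an ADME assay on Vero cells (Chlorocebus sabaeus) for cytotoxicity, read by resazurin assay, with a stated time of 72 h (on this read-out lower numbers stand for higher toxicity in this test and higher numbers for lower toxicity in this test), compound 1 reaches only a limit of the test, not a number. Within the data shown here, compound 2 and compound 3 carry no result in this assay at all, so compound 1 is the sole compound of the three with any reading, and that reading is a limit: the limit of > 100000 nM in this assay, at which 1 of the 3 values shown sits. Among the measured compounds shown here, no step between two measured compounds can therefore be drawn, and nothing among the three shows how a change of the group on the aromatic ring of the shared core moves the read-out.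

Compound 4 `O=C(/C=C/c1ccc([N+](=O)[O-])o1)c1ccc(N2CCCCC2)cc1` is the unmeasured compound. It differs from compound 1 in one place: piperidin-1-yl in place of tert-butyl on an aromatic carbon. For the measured compounds named here, since compound 1 sits at the limit of this assay and no measured step is at hand, the account expects no step beyond the usual scatter in this assay for this change, in either direction. Compound 4 is expected to land at 100000 nM, with a likely range from 30000 nM to 300000 nM. The expected step is a number no higher from compound 1 to compound 4 (the limit leaves the size open), that is, essentially none. Whether compound 4 also returns only a limit rather than a number remains to be seen.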

Compound 4, half-maximal cytotoxic concentration: 349000 nM
Compound 4: the middle estimate sits 3.5-fold (0.54 log units) below what was measured; measured number outside the range, above it.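

In this assay, among these compounds, compound 1 gives only a limit and not a number, so no step from compound 1 to compound 4 can be read: the limit of > 100000 nM in this assay, at which 1 of the 4 values shown sits.

The compounds shown leave open how far, and in which direction, piperidin-1-yl in place of tert-butyl on an aromatic carbon moves the half-maximal cytotoxic concentration.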